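A few compounds are considered here, and "the series" means these few. Any claim that something is new, unique, unknown or untested is made for them only; others in the source may bear on it.

Two hydrazones built on one shared core have been measured. Compound 1 `COc1cc(/C=N/NC(=O)c2cnccn2)ccc1O` gives 63.5% in a functional assay on the whole organism (strain Swiss) for inhibition, with Mus musculus as the target, read by paw edema, with stated times of 40 min and 30 min, at a dose of 100 umol/kg by the oral route; on this read-out lower numbers stand for less inhibition and higher numbers for more inhibition at the one dose given (going by the name of the read-out). Compound 2 `O=C(N/N=C/c1ccc(-c2ccccc2)cc1)c1cnccn1` gives 47.7% in this assay, the lowest of the two numbers, and its gap to compound 1 lies beyond the scatter. Compound 3 `O=C(N/N=C/c1ccc(O)cc1)c1cnccn1` differs from compound 2 in one place: hydroxy in place of phenyl on an aromatic carbon. A rise is expected from this change because compound 1 also carries a hydroxy and gives 63.5%. The expected step is a number 9.3 percentage points higher from compound 2 to compound 3 (within the scatter). Compound 3 is therefore expected to give 57%, within a range from 45% to 69%.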

Compound 3, a percentage reported as inhibition, in the whole organism at one dose (the size of the read-out at that dose, not a potency): 42.3%
The estimate for compound 3 lay 14.7 percentage points above the measured number, and the stated range ends above it.
By their numbers in this assay, from the lowest: compounds 3 and 2 (each within the scatter of the next); then compound 1.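

Hydroxy in place of phenyl gives a number 5.4 percentage points lower from compound 2 to compound 3 (within the scatter) in this assay, so the two groups cannot be told apart on this aromatic carbon. Hydrogen in place of methoxy gives a number 21.2 percentage points lower from compound 1 to compound 3 (beyond the scatter), so a hydroxy alone does not match compound 1, and its higher number goes with the methoxy. Nothing available explains either step.

As far as these compounds go, it remains open whether methoxy is special or whether another group on that carbon, such as ethoxy or an amine, would serve as well. From the compounds shown here alone, it is also open how a carboxylic acid would fare in place of the hydroxy.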